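Swapping a sulfonate for a benzoate ester

The source may report more compounds than this note shows. Statements on the series, on what has been measured and on what is new or still open speak of the compounds shown alone.

Compound 2 `CC(C)S(=O)(=O)OC1CCC(CN2CCN(c3cc(=O)c4cc(C(F)(F)F)cc([N+](=O)[O-])c4s3)CC2)CC1` is the starting point. In an ADME assay on Vero cells (Chlorocebus sabaeus) for cytotoxicity, read by MTT assay, with a stated time of 48 h (on this read-out lower numbers stand for stronger inhibition and higher numbers for weaker inhibition), compound 2 gives > 64 ug/mL, which is a limit of the assay rather than a number. Its neighbour compound 1 `O=c1cc(N2CCN(CC3CCC(OS(=O)(=O)c4cccnc4)CC3)CC2)sc2c([N+](=O)[O-])cc(C(F)(F)F)cc12` likewise gives only a limit in this assay, > 64 ug/mL. Going by the values given here, the single measured step, a step that the two limits leave unreadable from compound 1 to compound 2, therefore cannot be sized, since (the limit of > 64 ug/mL in this assay, at which 2 of the 2 values shown sit). Compound 3 `COc1ccccc1C(=O)OC1CCC(CN2CCN(c3cc(=O)c4cc(C(F)(F)F)cc([N+](=O)[O-])c4s3)CC2)CC1` differs from compound 2 by (2-methoxyphenyl)carbonyl in place of isopropylsulfonyl on an oxygen on a saturated carbon. Among the compounds with values here, no measured step bears on this change, so the expected step that the limit leaves unreadable from compound 2 to compound 3 is nothing beyond the scatter. Compound 3 is estimated at 100 ug/mL, within a range from 40 ug/mL to 250 ug/mL, most probably reported again as a limit.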

Compound 3, half-maximal inhibitory concentration: > 64 ug/mL
Compound 3 was reported as a limit (the forecaster's own chance of this, stated with the estimate: 80%); the middle value does not contradict the limit.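

Going by these compounds alone, no step can be sized among compound 1, compound 2 and compound 3, because all three give only a limit, not a number: the limit of > 64 ug/mL in this assay, at which 3 of the 3 values shown sit. Going by these compounds, what remains open is how strongly any of the three acts on these cells, and whether the (2-methoxyphenyl)carbonyl group in place of isopropylsulfonyl changes that at all.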